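The source may hold more compounds than are shown below. What is called first, only, known or untested is meant among the compounds shown, and "the series" means these compounds.

Compound 2 `Cc1ccc(C(=O)Nc2cccc(/C=C/C(=O)c3nc4ccccc4[nH]3)c2)cc1` and compound 1 `O=C(/C=C/c1cccc(NC(=O)c2ccccc2Br)c1)c1nc2ccccc2[nH]1` share a core and differ only in the group on the amide carbonyl carbon. In a functional assay on HCT-116 cells (Homo sapiens) for antiproliferative activity, read by MTT assay, with a stated time of 48 h (on this read-out higher numbers stand for weaker inhibition and lower numbers for stronger inhibition), compound 1 gives 1680 nM, and compound 2 gives 1660 nM; the two numbers lie within the usual scatter of each other, so neither compound can be set apart from the other on this read-out. For the measured compounds named here, the one measured step, a 1.0-fold lower number from compound 1 to compound 2 (0.01 log units; within the scatter), shows that exchanging the aryl group on the carbonyl carbon leaves the result unchanged beyond the scatter.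

Compound 3 `Cc1ccc(S(=O)(=O)Nc2cccc(/C=C/C(=O)c3nc4ccccc4[nH]3)c2)cc1` keeps the 4-methylphenyl group but changes the linkage to the aromatic nitrogen: (4-methylphenyl)sulfonyl in place of (4-methylphenyl)carbonyl on a nitrogen on an aromatic ring. Going by the values given here, no measured step touches the carbonyl itself, so the only guide is the near-flat behaviour of compound 1 and compound 2 in this assay, which gives no reason to expect movement in either direction. Compound 3 is therefore expected to give 1700 nM in this assay, within a range of 600 nM to 5000 nM; the expected step of a 1.0-fold higher number from compound 2 to compound 3 (0.01 log units; within the scatter) is thus none beyond the scatter.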

Compound 3, half-maximal inhibitory concentration: 1990 nM
Compound 3: middle estimate off by 1.2-fold (0.07 log units), on the low side; the measured number falls inside the stated range.
By their numbers in this assay, from the lowest: compounds 2, 1 and 3 (each within the scatter of the next).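

The earlier compounds shown here differed only in the aryl group on the amide carbonyl carbon, whereas compound 3 exchanges the linkage itself on the nitrogen on an aromatic ring. In this assay, (4-methylphenyl)sulfonyl in place of (4-methylphenyl)carbonyl gives a 1.2-fold higher number from compound 2 to compound 3 (0.08 log units; within the scatter), so on this read-out the sulfonyl linkage cannot be set apart from the carbonyl linkage when the 4-methylphenyl group stays the same. The change that replaces (2-bromophenyl)carbonyl with (4-methylphenyl)sulfonyl gives a 1.2-fold higher number from compound 1 to compound 3 (0.07 log units; within the scatter), which leaves all three compounds within the scatter of one another, and no information given here accounts for this result.

The compounds shown all carry an aryl group on this linkage, so it remains open whether the numbers would stay level with a small acetyl or methyl group on the nitrogen, or with a urea linkage in place of the amide. Going by these compounds, it also remains open whether a group such as a carboxylic acid or an amine on that aryl ring would move the number beyond the scatter.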